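The source may hold more compounds than are shown below. What is called first, only, known or untested is meant among the compounds shown, and "the series" means these compounds.

Measured so far in a functional assay on NCI-H23 cells (Homo sapiens) for antiproliferative activity, read by sulforhodamine B assay; on this read-out higher numbers stand for weaker inhibition of growth and lower numbers for stronger inhibition of growth:
Compound 1 `CC(C)CCCOc1cccc(O)c1C(=O)/C=C/c1ccc(O)cc1`: 11400 nM
Compound 2 `O=C(/C=C/c1ccc(O)cc1)c1c(O)cccc1OCC1CCCC1`: 3160 nM

Compound 2 holds the lower of these two numbers, so it inhibits growth more strongly than compound 1, and the gap lies beyond the scatter. Compound 3 `O=C(/C=C/c1ccc(O)cc1)c1c(O)cccc1OCc1ccccc1` keeps the shared core and alters one group: phenyl in place of cyclopentyl on a saturated chain carbon bound to an oxygen on an aromatic ring. Put simply, cyclopentylmethoxy becomes benzyloxy. Going by the values given here, only one measured step bears on this change, because it alters the same place: a 3.6-fold lower number from compound 1 to compound 2 (0.56 log units; beyond the scatter). That modest step shows that the number in this assay can move with this group. However, neither measured compound carries phenyl there, so no direction can be favoured. A step no larger than that one is expected, possibly none beyond the scatter. The expected change is a 1.1-fold higher number from compound 2 to compound 3 (0.04 log units; within the scatter). Compound 3 is therefore expected at about 3500 nM, with an estimated range of 1200 nM to 10000 nM.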

Compound 3, concentration for 50% growth inhibition: > 30000 nM
Compound 3: a limit, no number; the forecaster's own chance of this, stated with the estimate: 5%; at least 8.5-fold (0.93 log units) between middle value and limit.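

Compound 3 carries only a limit, not a number, in this assay: the limit of > 30000 nM in this assay, at which 1 of the 3 values shown sits. The earlier pair showed that this group can move the number, but not what a phenyl ring would do here. Now the direction is clear: phenyl in place of cyclopentyl gives an at least 9.4-fold higher number from compound 2 to compound 3 (0.97 log units; beyond the scatter), and phenyl in place of isopentyl gives an at least 2.6-fold higher number from compound 1 to compound 3 (0.42 log units; beyond the scatter), so of the three groups shown, phenyl gives the weakest inhibition of growth, whether it replaces a ring or an open chain.

The compounds shown leave open whether cyclohexyl, a six-membered ring of carbon that is not aromatic, would read like compound 2 or like compound 3, so ring size and aromatic character are not separated here. From the compounds shown here alone, it also remains open how a pyridyl ring or an amine-bearing chain would read at this place.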